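Carbamoylmethyl in Place of (Ethoxycarbonyl)methyl

This account rests on a few compounds, and the source may have more. Where it says the series, first, only, none or still open, it means among the compounds named here.

Of the compounds shown here, two have been measured so far in a functional assay on the whole organism (B cells) with Mus musculus as the target; a lower number here means a smaller maximal response, a higher number a larger maximal response. Compound 1 `CCOC(=O)Cn1c(=O)n(C2OC(CO)[C@@H](O)[C@H]2O)c2nc(N)nc(O)c21` gives 86% in this assay. Compound 2 `C=CCn1c(=O)n(C2C[C@H](O)C(CO)O2)c2nc(N)nc(O)c21` gives 99% in this assay. Compound 1 therefore stands lowest of the two numbers, and compound 2 lies above it by a margin beyond the usual scatter. Among the compounds with values here, the two differ from each other in more than one place, so no single step between them can be read off, and nothing in the measured pair isolates a change of the kind described next.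

Compound 3 `NC(=O)Cn1c(=O)n(C2OC(CO)[C@@H](O)[C@H]2O)c2nc(N)nc(O)c21` has not yet been measured. It differs from compound 1 in one place: amino in place of ethoxy on a carbonyl carbon. The rest of the shared core and of the remaining substituents is unchanged.

Within the data shown here, with no measured step to lean on, only a cautious expectation is possible. Since compound 1 already reaches 86%, the step is expected to be small, likely within the scatter, and in either direction: a number 4 percentage points higher from compound 1 to compound 3 (within the scatter). Compound 3 is thus estimated at 90%, within a range from 74% to 106%.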

Compound 3, largest response reached (reported as maximal response), in percent of the reference or control that the assay uses: 32%
The estimate for compound 3 lay 58 percentage points above the measured number; the whole stated range lies above it.
By their numbers in this assay, from the lowest: compound 3; then compound 1; then compound 2.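

In this assay, within the data shown here, amino in place of ethoxy on a carbonyl carbon gives a number 54 percentage points lower from compound 1 to compound 3 (beyond the scatter) while the rest of the molecule stays unchanged, which makes this the first change that can be read at a single place. It shows that the maximal response depends strongly on what this carbonyl carbon carries, so the high number of compound 1 cannot be credited to the shared core alone and is tied to the (ethoxycarbonyl)methyl group as a whole. Nothing available on these compounds accounts for the size of this step, so the result stands as an observation without an explanation.

On these data alone, what remains open is whether the response falls on gaining amino or on losing ethoxy, a question that methoxy, a longer alkoxy chain, methylamino, dimethylamino or the free carboxylic acid on the same carbonyl carbon would help to separate. As far as these compounds go, it is also open whether a longer chain between the carbonyl carbon and the shared core would change the size of the step from ethoxycarbonyl to carbamoyl.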